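The source may report more compounds than this note shows. Statements on the series, on what has been measured and on what is new or still open speak of the compounds shown alone.

Measured in a functional assay on BV-2 cells (Mus musculus), read by Griess assay, with a stated time of 24 h; a lower number here means a stronger inhibitor, a higher number a weaker inhibitor:
- compound 1 `O=C1C=CC2(C=C1)OCC(Cc1ccccc1)C(=O)N2c1ccccc1`: 570 nM
- compound 2 `O=C1C=CC2(C=C1)OCC(Cc1ccc(Br)cc1)C(=O)N2c1ccccc1`: 1380 nM

Not yet measured: compound 3 `O=C1C=CC2(C=C1)OCC(Cc1ccccc1CS(=O)(=O)c1ccccc1)C(=O)N2c1ccccc1`.

Of the two measured compounds, compound 1 holds the lower number at 570 nM, so it is the stronger inhibitor in this assay. Compound 3 keeps the core of compound 1 and changes it in one place: (phenylsulfonyl)methyl in place of hydrogen on an aromatic carbon. This puts (phenylsulfonyl)methyl in place of hydrogen on an aromatic carbon, ortho to a large group.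

Going by the values given here, only one measured step bears on this change: a 2.4-fold higher number from compound 1 to compound 2 (0.38 log units; beyond the scatter), a modest loss on replacing hydrogen with bromo on an aromatic carbon. That single step is thin evidence, and the entering group here is far larger than bromo. A modest rise in the number is therefore expected, with wide uncertainty. The expected change is a 2.6-fold higher number from compound 1 to compound 3 (0.42 log units; beyond the scatter).

For compound 3 the estimated value is 1500 nM, with an expected range of 400 nM to 6000 nM.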

Compound 3, half-maximal inhibitory concentration: 980 nM
For compound 3 the middle estimate is 1.5-fold (0.18 log units) above the measured one; the range from low to high includes it.
By their numbers in this assay, from the lowest: compounds 1, 3 and 2 (each within the scatter of the next, the first and the last beyond it).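

In this assay, (phenylsulfonyl)methyl on an aromatic carbon, ortho to a large group, gives a 1.7-fold higher number from compound 1 to compound 3 (0.24 log units; within the scatter) and so cannot be told apart from hydrogen at this place. Going by these compounds alone, the only earlier step, a 2.4-fold higher number from compound 1 to compound 2 (0.38 log units; beyond the scatter) for bromo in place of hydrogen, lay beyond the scatter and involved a far smaller group at a different place. Across these compounds the size of the entering group therefore does not track the step, and this position accepts a substituent carrying its own six-membered aromatic ring with no change beyond the scatter.

Still open, from the compounds shown here alone, is which part of the group matters here, which a simple methyl or an aminomethyl at the same place would help to separate. Nothing available explains why this large group leaves the number within the scatter.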